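A few compounds are considered here, and "the series" means these few. Any claim that something is new, unique, unknown or untested is made for them only; others in the source may bear on it.

Compound 3 `COC(=O)CNC1=CS(=O)(=O)O[C@@]12[C@@H](CO[Si](C)(C)C(C)(C)C)O[C@@H](n1cc(C)c(=O)n(C)c1=O)[C@@H]2O[Si](C)(C)C(C)(C)C` is one of three compounds whose cytotoxicity toward HEL cells was recorded in a functional assay on HEL cells (Homo sapiens) for cytotoxicity, read by microscopy; on this read-out lower numbers stand for higher toxicity in this test and higher numbers for lower toxicity in this test. In this assay compound 3 gives only a limit, >= 400000 nM. Compound 1 `CC(=O)NC1=CS(=O)(=O)O[C@@]12[C@@H](CO[Si](C)(C)C(C)(C)C)O[C@@H](n1cc(C)c(=O)n(C)c1=O)[C@@H]2O[Si](C)(C)C(C)(C)C` differs from compound 3 solely in the group on the amine nitrogen. In this assay compound 1 likewise gives a limit, >= 80000 nM. Compound 2 `Cc1cn([C@@H]2O[C@@H]3COC(=O)[C@]3(OS(C)(=O)=O)[C@H]2O)c(=O)[nH]c1=O` is the third measured compound. In this assay compound 2 gives a limit, >= 400000 nM. The step that the two limits leave unreadable from compound 1 to compound 3 cannot be read from two limits. Compound 3 therefore stands at the limit of >= 400000 nM in this assay, at which 2 of the 3 values shown sit, whereas compound 1 sits at the limit of >= 80000 nM in this assay, at which 1 of the 3 values shown sits.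

Compound 4 `Cc1cn([C@@H]2O[C@H](CO[Si](C)(C)C(C)(C)C)[C@@]3(OS(=O)(=O)C=C3NC(N)=O)[C@H]2O[Si](C)(C)C(C)(C)C)c(=O)n(C)c1=O` follows from compound 3 by carbamoyl in place of (methoxycarbonyl)methyl on an amine nitrogen. Among the compounds with values here, the only measured step at this nitrogen, a step that the two limits leave unreadable from compound 1 to compound 3, has no readable size, so no shift beyond the scatter is foreseen in this assay, and compound 4 is expected to give a limit as well. Compound 4 is therefore estimated at 400000 nM, with a range from 100000 nM to 400000 nM. The step of a number no higher from compound 3 to compound 4 (the limit leaves the size open) is accordingly expected to be nil.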

Compound 4, minimum cytotoxic concentration: 16000 nM
Beside the measured number, compound 4's estimate is 25-fold (1.40 log units) above it; measured number outside the range, below it.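

In this assay the group on the amine nitrogen now proves able to move the read-out, which the earlier limits alone could not show. Carbamoyl in place of (methoxycarbonyl)methyl gives an at least 25-fold lower number from compound 3 to compound 4 (1.39 log units; beyond the scatter), and amino in place of methyl on a carbonyl carbon gives an at least 5.0-fold lower number from compound 1 to compound 4 (0.69 log units; beyond the scatter), so among these three the ureido group goes with the highest toxicity in this test. Compound 3 gives only a limit, so the larger step states a minimum size and not a full one: the limit of >= 400000 nM in this assay, at which 2 of the 4 values shown sit.

The compounds shown leave open how a methylureido group, or a free primary amine, on this nitrogen would read. They also leave open whether the same change would hold on a core carrying free hydroxyl groups in place of the tert-butyldimethylsilyl ethers.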